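Fluoropiperidine in place of dihydropyrrole on the thienopyrimidine series

The source may hold more compounds than are shown below. What is called first, only, known or untested is meant among the compounds shown, and "the series" means these compounds.

Measured so far:
compound 1, `Nc1nc(-c2ccc(Cl)o2)nc2sc(CN3CCC(F)CC3)cc12`, 1080 nM
compound 2, `N#Cc1cccc(-c2nc(N)c3cc(CN4CC=CC4)sc3n2)c1`, 2070 nM

Both numbers come from an assay on CHO-K1 cells for antagonist activity at adenosine receptor A1 (Homo sapiens), read by a beta-galactosidase reporter, with stated times of 15 min and 6 h; a lower number here means a stronger inhibitor, a higher number a weaker inhibitor. Of the two, compound 2 has the higher number, but its gap to compound 1 falls within the usual scatter, so the two compounds cannot be told apart on these values. For the measured compounds named here, compound 1 and compound 2 differ in two places at once, so no single step between them can be read off.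

Compound 3, `N#Cc1cccc(-c2nc(N)c3cc(CN4CCC(F)CC4)sc3n2)c1`, is the not yet measured member. It keeps the aryl substituent of compound 2 and carries the change (a group of 7 heavy atoms (5 carbon, 1 nitrogen, 1 fluorine; one six-membered non-aromatic ring with 1 hetero atom) in place of a group of 5 heavy atoms (4 carbon, 1 nitrogen; one five-membered non-aromatic ring with 1 hetero atom), on a saturated chain carbon bound to an aromatic carbon). Compound 1 already bears the 4-fluoropiperidin-1-yl group, though with a different aryl group, and compound 1 gives 1080 nM in this assay; that is the only hint available, and it does not isolate the effect of the ring exchange.

Expectation for the step: no change beyond the scatter, with at most a slight lean toward a lower number, a 1.4-fold lower number from compound 2 to compound 3 (0.14 log units; within the scatter). Compound 3 is therefore estimated at 1500 nM, with a range from 500 nM to 4500 nM.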

Compound 3, inhibition constant: 2950 nM
For compound 3 the middle estimate is 2.0-fold (0.29 log units) below the measured one, and the stated range covers the measured number.
By their numbers in this assay, from the lowest: compounds 1, 2 and 3 (each within the scatter of the next, the first and the last beyond it).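

In this assay the 4-fluoropiperidin-1-yl group in place of the five-membered ring, on a saturated chain carbon bound to an aromatic carbon, gives a 1.4-fold higher number from compound 2 to compound 3 (0.15 log units; within the scatter) and so does not separate the two rings while 3-cyanophenyl is held constant. For the compounds shown here, with 4-fluoropiperidin-1-yl held constant, the exchange on the aromatic carbon gives the first single-place step beyond the scatter, with 3-cyanophenyl in place of 5-chlorofuran-2-yl producing a 2.7-fold higher number from compound 1 to compound 3 (0.44 log units; beyond the scatter) in this assay as a modest change, so in this small set the aromatic substituent registers where the ring on the chain carbon does not. No supporting measurement offers a reason for either step.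

Whether the ring exchange stays within the scatter with 5-chlorofuran-2-yl on the aromatic carbon remains open, as the compounds shown offer that comparison only with 3-cyanophenyl. From the compounds shown here alone, the contribution of the fluorine also remains open and would need an unsubstituted piperidin-1-yl group on the same chain carbon, while a morpholin-4-yl group there would test whether a further ring hetero atom moves the number beyond the scatter.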